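This account rests on a few compounds, and the source may have more. Where it says the series, first, only, none or still open, it means among the compounds named here.

Measured so far in a functional assay on PC-3 cells (Homo sapiens) for inhibition, read by sulforhodamine B assay; on this read-out higher numbers stand for weaker inhibition of growth and lower numbers for stronger inhibition of growth:

- compound 1 `O=C(CCC1=CCCN(Cc2ccc(F)cc2)C1=O)NO`: "not determined" (no result reported)
- compound 2 `O=C(CCC1=CCCN(CCCCc2cccc3ccccc23)C1=O)NO`: 1690 nM

The series therefore starts without a usable reference point. In this assay compound 1 has no number at all, and its entry reads "not determined" (no result reported). Within the data shown here, compound 1 cannot be ranked against compound 2, and no measured step exists to show how sensitive this read-out is to a change in structure.

Compound 3 `O=C(CCC1=CCCN(Cc2ccc([N+](=O)[O-])cc2)C1=O)NO` has yet to be measured. It differs from the starting structure in a single place, with nitro in place of fluoro on an aromatic carbon.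

Since compound 1 has no number, any step from it would remain unmeasured even after a result for compound 3 arrives. In principle, a small step is expected in this assay, perhaps none beyond the scatter, and the data give no direction for it. Among the measured compounds shown here, the only anchor is compound 2 at 1690 nM, and it carries a quite different group on the shared core, so the estimate must stay wide. For compound 3 the expected value is 5000 nM, with an estimated range from 1500 nM to 20000 nM.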

Compound 3, concentration for 50% growth inhibition: 3010 nM
Compound 3: middle estimate off by 1.7-fold (0.22 log units), on the high side; measured number inside the range.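

In this assay, among these compounds, compound 3 gives 3010 nM while compound 1 has no number, so no step between these two compounds can be read. No available measurement offers an explanation for the value of compound 3. Going by these compounds, whether nitro in place of fluoro on the aromatic carbon changes growth inhibition stays open.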